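Trifluoromethyl on the phenyl ring: compound 2 to compound 3

A few compounds are considered here, and "the series" means these few. Any claim that something is new, unique, unknown or untested is made for them only; others in the source may bear on it.

Of the compounds shown here, two from this series have been tested in a functional assay on B16-F10 cells (Mus musculus) for cytotoxicity, read by MTT assay, with a stated time of 48 h (a lower number here means a stronger inhibitor, a higher number a weaker inhibitor), so far. Compound 1 `O=C(/C=C\Nc1ccc(Cl)cc1)c1nc(-c2ccc(C(F)(F)F)cc2)n2ccccc12` carries a 4-(trifluoromethyl)phenyl group together with a chlorophenyl aniline. In this assay compound 1 gives > 30000 nM, which is a limit of the assay and not a number. Going by the values given here, compound 2 `COc1ccc(N/C=C\C(=O)c2nc(-c3ccccc3)n3ccccc23)cc1` is the only compound with a real number: in this assay compound 2 gives 1790 nM. Among the compounds with values here, the one other value recorded, that of compound 1, is a limit, (the limit of > 30000 nM in this assay, at which 1 of the 2 values shown sits).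

Compound 3 `COc1ccc(N/C=C\C(=O)c2nc(-c3ccc(C(F)(F)F)cc3)n3ccccc23)cc1` has not yet been measured. It differs from compound 2 by trifluoromethyl in place of hydrogen on an aromatic carbon; the same change, read one bond further out, turns phenyl into 4-(trifluoromethyl)phenyl. Within the data shown here, no measured pair in this set isolates this change. The trifluoromethyl group is, however, already present in compound 1, whose result in this assay, > 30000 nM, is a limit. On that basis compound 3 is expected to be weaker than compound 2, with a step of a 3.4-fold higher number from compound 2 to compound 3 (0.53 log units; beyond the scatter) that is estimated to lie beyond the scatter. Compound 3 is therefore estimated at 6000 nM in this assay, with a range from 1500 nM to 30000 nM, and a real chance that only a limit is reported.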

Compound 3, half-maximal inhibitory concentration: > 30000 nM
Compound 3 was reported as a limit (the forecaster's own chance of this, stated with the estimate: 35%); at least 5.0-fold (0.69 log units) between middle value and limit.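

In this assay, going by these compounds alone, this is the first pair that isolates trifluoromethyl in place of hydrogen on an aromatic carbon, para to a large group, and the change gives an at least 16-fold higher number from compound 2 to compound 3 (1.22 log units; beyond the scatter). Going by these compounds, the value of compound 3 is a limit and not a number, so this step fixes only the smallest size of the change, and its full size stays unknown. Compound 1 and compound 3, which differ by methoxy in place of chloro, both stand at a limit, so the step between them cannot be read, and compound 2 alone keeps a real number: the limit of > 30000 nM in this assay, at which 2 of the 3 values shown sit.

On these data alone, what stays open is whether this loss is particular to trifluoromethyl: a single fluorine, a methyl, an amine or a carboxylic acid at the same place on the phenyl ring could either keep a real number in this assay or also reach the limit. As far as these compounds go, it is also open how chloro in place of methoxy would read on a compound whose phenyl ring carries no trifluoromethyl, with a real number on both sides of the comparison.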